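A Smaller Amine on the Core: Compound 1 to Compound 4

This account rests on a few compounds, and the source may have more. Where it says the series, first, only, none or still open, it means among the compounds named here.

In a functional assay on HCT-116 cells (Homo sapiens) for inhibition, read by luminescence and resazurin assay, with a stated time of 3 days (a lower number here means a stronger inhibitor, a higher number a weaker inhibitor), the measured compounds gave the following.
Compound 1 (`Cc1ccc2nc(N3CCNC(C)C3)nc(NCc3ccc(C(=O)NC4CCN(Cc5ccc(F)cc5)CC4)cc3)c2c1`): 2000 nM.
Compound 2 (`CNc1nc2ccccc2c(NCc2ccc(NC(=O)c3ccc(F)cc3)cc2)c1C#N`): > 20000 nM, which is a limit of the assay and not a number.
Compound 3 (`CCCNc1nc2ccccc2c(NCc2ccc(NC(=O)c3ccc(F)cc3)cc2)c1C#N`): > 20000 nM, likewise a limit of the assay.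

Within the data shown here, compound 1 stands alone as the only value that is an actual number; the other two results are limits, as the limit of > 20000 nM in this assay, at which 2 of the 3 values shown sit, records. Among the measured compounds shown here, the one pairwise step among measured compounds, a step that the two limits leave unreadable from compound 2 to compound 3, is therefore unreadable and says nothing about size or direction.

Compound 4 (`CNc1nc(NCc2ccc(C(=O)NC3CCN(Cc4ccc(F)cc4)CC3)cc2)c2cc(C)ccc2n1`) keeps the core of compound 1 and changes a single group: methylamino in place of 3-methylpiperazin-1-yl on an aromatic carbon. For the measured compounds named here, no measured step touches this kind of change, so there is no measured size to carry over. Compounds 2 and 3 carry methylamino and propylamino groups on a different core, and both sit at the limit, which is the only hint available; it is not a measured step.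

With that in mind, compound 4 is expected to be a weaker inhibitor than compound 1, with an estimated step of a 3.0-fold higher number from compound 1 to compound 4 (0.48 log units; beyond the scatter). The estimate for compound 4 in this assay is 6000 nM, within a range from 1500 nM to 20000 nM.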

Compound 4, half-maximal inhibitory concentration: 1200 nM
Compound 4: the middle estimate sits 5.0-fold (0.70 log units) above what was measured; the whole stated range lies above it.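

In this assay, the comparison gives a 1.7-fold lower number from compound 1 to compound 4 (0.22 log units; within the scatter), so the two compounds cannot be told apart in this assay. Among these compounds, until now the core of compound 1 had only a single number, which could not show whether the group on the aromatic carbon between two ring nitrogen atoms matters to the reading; this pair gives the first answer, as the whole 3-methylpiperazin-1-yl ring can give way to the much smaller, ring-free methylamino group with no readable change. Nothing measured here explains why the reading holds steady across this swap, and the result should be taken only as an observation about this one pair.

The compounds shown leave open how other groups on the same carbon would read, such as a plain amino group, a piperazin-1-yl ring without its methyl, or a morpholin-4-yl ring, any of which would help show how far this tolerance extends. A single pair on a single core also cannot say whether the same swap would read alike on a different core.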